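Side-chain exchange from compound 3 to compound 4

The source may report more compounds than this note shows. Statements on the series, on what has been measured and on what is new or still open speak of the compounds shown alone.

Of the compounds shown here, three sharing a closely related core have been measured so far: compound 1 (`NCCCCN(C[C@@H]1Cc2ncccc2CN1)[C@H]1CCCc2cccnc21`), compound 2 (`NCCCCN(C[C@H]1Cc2nccnc2CN1)[C@H]1CCCc2cccnc21`) and compound 3 (`NC/C=C/CN(C[C@H]1Cc2ncccc2CN1)[C@H]1CCCc2cccnc21`). In an ADME assay on microsomes from liver (Homo sapiens) for metabolic stability, using NADPH, with a stated time of 10 min (a higher number here means that more of the compound is left, a lower number that less of the compound is left), compound 3 gives 85%. That value lies within the scatter of compound 2 at 84%, and clearly under compound 1 at 98%.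

The next compound is compound 4 (`CCN(CC)CCCCN(C[C@H]1Cc2ncccc2CN1)[C@H]1CCCc2cccnc21`), which carries 3-(diethylamino)propyl in place of 3-aminoprop-1-en-1-yl on a saturated chain carbon bound to an amine nitrogen.

Among the compounds with values here, no two measured compounds differ in one place only, so the series offers no direct precedent for this exchange. The expectation rests on the level of compound 3 at 85% and on the size of the change, and it remains uncertain. A fall beyond the scatter in this assay is expected, with an estimated a number 13 percentage points lower from compound 3 to compound 4 (beyond the scatter).

For compound 4 the expected value is 72%, with an estimated range of 52% to 90%.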

Compound 4, percent of the compound remaining: 80%
Beside the measured number, compound 4's estimate is 8 percentage points below it; measured number inside the range.
By their numbers in this assay, from the lowest: compounds 4, 2 and 3 (each within the scatter of the next); then compound 1.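

In this assay, within the data shown here, 3-(diethylamino)propyl in place of 3-aminoprop-1-en-1-yl on a saturated chain carbon bound to an amine nitrogen gives a number 5 percentage points lower from compound 3 to compound 4 (within the scatter), the first step between compounds differing in one place. This place therefore accepts the larger group, which has no hydrogen-bond donor and no double bond outside aromatic rings, while compound 3 and compound 4 remain within the scatter of each other. Nothing available explains the result.

Going by these compounds, the step removes the double bond and brings in the diethylamino group together, so the contribution of each stays open. On these data alone, how a chain ending in a hydroxyl group or a carboxylic acid would read in this assay also remains open.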